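Oral exposure: from compound 2 to compound 3

The source may report more compounds than this note shows. Statements on the series, on what has been measured and on what is new or still open speak of the compounds shown alone.

In an ADME assay on the whole organism (strain Sprague-Dawley) for pharmacokinetics, with Rattus norvegicus as the target, read by LC-MS, at a dose of 50 mg/kg by the oral route (a lower number here means that a smaller share of the oral dose reaches the circulation, a higher number that a larger share of the oral dose reaches the circulation), compound 1 `CCC(CC)O[C@@H]1C=C(C(=O)O)C[C@H](NC(C)=N)[C@H]1NC(C)=O` gives 3.9%. Compound 2 `CCOC(=O)C1=C[C@@H](OC(CC)CC)[C@H](NC(C)=O)[C@@H](N/C(N)=N\O)C1` gives 1.5%, within the usual scatter of compound 1. Compound 3 `CCOC(=O)C1=C[C@@H](OC(CC)CC)[C@H](NC(C)=O)[C@@H](NC(=N)N)C1` awaits measurement. It differs from compound 2 on an amine nitrogen whose other neighbours are a saturated ring carbon: a group of 3 heavy atoms (1 carbon, 2 nitrogen; no ring) in place of a group of 4 heavy atoms (1 carbon, 2 nitrogen, 1 oxygen; no ring), on an amine nitrogen. For the measured compounds named here, no single-place step between measured compounds is available to size this change. Going by the values given here, the only guide is that compound 1 at 3.9% and compound 2 at 1.5% lie within the scatter of each other. An estimated a number 2.5 percentage points higher from compound 2 to compound 3 (within the scatter) is expected in this assay, upward but not beyond the scatter. Compound 3 is expected at 4%, with an estimated range of 1% to 12%.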

Compound 3, oral bioavailability: 1.3%
Estimate against measurement, compound 3: 2.7 percentage points above; the measured number falls inside the stated range.
By their numbers in this assay, from the lowest: compounds 3, 2 and 1 (each within the scatter of the next).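

In this assay, for the compounds shown here, this is the first single-place step, on an amine nitrogen whose other neighbours are a saturated ring carbon: a number 0.2 percentage points lower from compound 2 to compound 3 (within the scatter) when the group of 3 heavy atoms replaces the group of 4 heavy atoms. At this position, the loss of the oxygen therefore produces no readable change in oral bioavailability. Nothing measured bears on the reason for this result. Still open, on these data alone, is whether a methyl group or a longer alkyl chain on this amine nitrogen would give a number beyond the scatter of compound 2.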